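The source may report more compounds than this note shows. Statements on the series, on what has been measured and on what is new or still open speak of the compounds shown alone.

Values measured in a functional assay on KB cells (Homo sapiens) for antiproliferative activity, read by sulforhodamine B assay, with a stated time of 3 days (on this read-out lower numbers stand for stronger inhibition of growth and higher numbers for weaker inhibition of growth), are as follows.
- Compound 1 `O=C(Nc1nccs1)c1cccc(Nc2ncc(F)c(Nc3ccc(F)cc3)n2)c1` gives > 10000 nM, a limit
- Compound 2 `O=C(Nc1cccc(Nc2ncc(F)c(Nc3ccc(F)cc3)n2)c1)c1ccncc1` gives 5280 nM
- Compound 3 `O=C(Nc1cccc(Nc2ncc(F)c(Nc3ccc(F)cc3)n2)c1)c1ccccc1` gives > 10000 nM, a limit

Compound 3 yields no number, only the limit > 10000 nM, and it stands with compound 1 at the limit of > 10000 nM in this assay, at which 2 of the 3 values shown sit. Compound 4 `O=C(NCCO)c1cccc(Nc2ncc(F)c(Nc3ccc(F)cc3)n2)c1` carries (2-hydroxyethyl)carbamoyl in place of benzamido on an aromatic carbon, meta to a large group, a change counted as (2-hydroxyethyl)carbamoyl in place of benzamido on an aromatic carbon.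

Within the data shown here, three measured steps bear on this change, and none gives a readable size beyond the scatter. Placing phenyl in place of pyridin-4-yl on a carbonyl carbon gave an at least 1.8-fold higher number from compound 2 to compound 3 (0.27 log units; that floor lies within the scatter). The change from (1,3-thiazol-2-yl)carbamoyl to ((pyridin-4-yl)carbonyl)amino gave an at least 1.8-fold lower number from compound 1 to compound 2 (0.27 log units; that floor lies within the scatter). The third is a step that the two limits leave unreadable from compound 1 to compound 3. Among the measured compounds shown here, compound 1, the only measured compound that also bears a carbamoyl group at this place, reports the limit > 10000 nM.

No step beyond the scatter is therefore expected in this assay, in either direction, and a further limit would be no surprise. The expected change is a number no higher from compound 3 to compound 4 (the limit leaves the size open). For compound 4 the estimate is 10000 nM, with an expected range from 4000 nM to 25000 nM.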

Compound 4, concentration for 50% growth inhibition: 12400 nM
Compound 4: the middle estimate sits 1.2-fold (0.09 log units) below what was measured; measured number inside the range.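

In this assay, among these compounds, compound 4 gives 12400 nM, a number and not a limit, and so the only measured value shown for a carbamoyl group on this aromatic carbon. Among the compounds shown here, the one step that can be read is a 2.3-fold higher number from compound 2 to compound 4 (0.37 log units; beyond the scatter), so (2-hydroxyethyl)carbamoyl in place of ((pyridin-4-yl)carbonyl)amino gives a modest rise in the number, and the change of group at this place has a measurable size for the first time. The two steps that reach compound 4 from the remaining compounds cannot be read, each having a limit at one end: the limit of > 10000 nM in this assay, at which 2 of the 4 values shown sit.

As far as these compounds go, it stays open whether an amine or a carboxylic acid at the end of the 2-hydroxyethyl chain, or a longer chain on the amide-type nitrogen, would move the number in this assay in either direction. From the compounds shown here alone, it also stays open how far benzamido and (1,3-thiazol-2-yl)carbamoyl lie from (2-hydroxyethyl)carbamoyl at this place, since those groups are known here only through limits.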